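The source may hold more compounds than are shown below. What is called first, only, known or untested is meant among the compounds shown, and "the series" means these compounds.

Of the compounds shown here, two have been measured so far in an in vitro ADME assay on microsomes from liver (Homo sapiens) for metabolic stability, tested at 5 uM; a lower number here means that the compound disappears faster, a higher number that the compound lasts longer. There, compound 1 `CC(C)CCn1nc(CC(C)C)c(O)c(C2=NS(=O)(=O)c3cc(NS(C)(=O)=O)ccc3N2)c1=O` gives 0.123 h. Compound 2 `CCC(C)CCn1nc(-c2cccs2)c(O)c(C2=NS(=O)(=O)c3cc(NS(C)(=O)=O)ccc3N2)c1=O` gives > 1 h, which is a limit of the measurement and not an exact number. That places compound 2 at the limit of > 1 h in this assay, at which 1 of the 2 values shown sits. Of the two, compound 2 lasts longer, but the pair differs in more than one place, so their values do not isolate the effect of any single group.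

Compound 3 `CCC(C)n1nc(-c2cccs2)c(O)c(C2=NS(=O)(=O)c3cc(NS(C)(=O)=O)ccc3N2)c1=O` keeps the thiophen-2-yl group of compound 2 and changes one thing, with sec-butyl in place of 3-methylpentyl on an aromatic nitrogen. Within the data shown here, no measured pair shows this change on its own, so the expectation is a cautious one. It starts from compound 2, whose > 1 h is a limit. The expected change, an at least 1.1-fold lower number from compound 2 to compound 3 (0.04 log units; that floor lies within the scatter), is small and stays within the usual scatter, with no firm direction. The half-life estimated for compound 3 is 0.9 h, with an expected range from 0.3 h to 2.5 h.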

Compound 3, half-life: > 1 h
Compound 3: only a limit was reported (the forecaster's own chance of this, stated with the estimate: 50%); middle value at least 1.1-fold (0.04 log units) away from the limit.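

In this assay compound 3 gives > 1 h, which is a limit and not an exact number. Compound 2 also has only a limit, so no step can be read between compound 2 and compound 3: the limit of > 1 h in this assay, at which 2 of the 3 values shown sit.

The compounds shown leave open the true half-lives of both compounds, and whether sec-butyl in place of 3-methylpentyl changes the half-life at all.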